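From Compound 3 to Compound 4: A Swapped Phenyl Group

This account rests on a few compounds, and the source may have more. Where it says the series, first, only, none or still open, it means among the compounds named here.

Compound 1 `N#Cc1ccc(F)cc1Cn1c(N2CCC[C@@H](N)C2)nc2c(-c3ccc(F)cc3)c[nH]c2c1=O`, compound 2 `N#Cc1ccc(F)cc1Cn1c(N2CCC[C@@H](N)C2)nc2cc[nH]c2c1=O` and compound 3 `CS(=O)(=O)c1ccc(-c2c[nH]c3c(=O)n(Cc4cc(F)ccc4C#N)c(N4CCC[C@@H](N)C4)nc23)c(F)c1` share one core and differ only at a single aromatic carbon. In an ADME assay on microsomes from liver (Rattus norvegicus) for metabolic stability, read by LC-MS, tested at 1 mM (a lower number here means that the compound disappears faster, a higher number that the compound lasts longer), compound 1 gives 1.21 h. Going by the values given here, compound 3 gives 1.59 h, and these two readings, the only plain numbers so far, lie within the usual scatter of each other, so neither can be said to last longer. Compound 2 gives > 1 h, which is a limit of the assay and not a number.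

Compound 4 `CS(=O)(=O)c1ccccc1-c1c[nH]c2c(=O)n(Cc3cc(F)ccc3C#N)c(N3CCC[C@@H](N)C3)nc12` has not yet been measured. It carries 2-(methylsulfonyl)phenyl in place of 2-fluoro-4-(methylsulfonyl)phenyl on an aromatic carbon, two ring bonds from the ring nitrogen: 2-(methylsulfonyl)phenyl in place of 2-fluoro-4-(methylsulfonyl)phenyl on an aromatic carbon.

Two of the measured steps offer no size to work with: a step that the limit leaves unreadable from compound 1 to compound 2, and a step that the limit leaves unreadable from compound 2 to compound 3. Among the compounds with values here, the one readable step is a 1.3-fold higher number from compound 1 to compound 3 (0.12 log units; within the scatter), where one substituted phenyl group took the place of another, so a further swap of this kind is expected to give no step beyond the scatter in this assay. The estimated step is a 1.1-fold lower number from compound 3 to compound 4 (0.06 log units; within the scatter). Compound 4 is expected at 1.4 h, with an estimated range from 0.7 h to 2.8 h.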

Compound 4, half-life: 3.29 h
Compound 4: middle estimate off by 2.4-fold (0.37 log units), on the low side; the measured number lies above the stated range.
By their numbers in this assay, from the lowest: compounds 1 and 3 (each within the scatter of the next); then compound 4.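

Going by these compounds alone, the swap at this aromatic carbon is not always silent: in this assay, 2-(methylsulfonyl)phenyl in place of 2-fluoro-4-(methylsulfonyl)phenyl gives a 2.1-fold higher number from compound 3 to compound 4 (0.32 log units; beyond the scatter), the first step at this position that clearly exceeds the usual variation between repeat measurements. Compound 4 also separates from the 4-fluorophenyl analogue, with a 2.7-fold higher number from compound 1 to compound 4 (0.43 log units; beyond the scatter), whereas compound 1 and compound 3 could not be told apart, so a substituted phenyl group here does not guarantee the same half-life, and the exact form of the group matters. Going by these compounds, compound 2 gives > 1 h, which is a limit and not a number, so the steps that start from compound 2 cannot be read and the effect of having any phenyl group at this position, compared with hydrogen, remains unknown.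

Nothing measured here explains the rise in half-life. The two groups differ both in the fluorine and in the placing of the methylsulfonyl, so the compounds shown cannot separate these two changes, and they leave open whether a sulfonamide or a carboxylic acid in place of the methylsulfonyl would last as long.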